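Compound 3 to compound 4: an estimate from one number

This account rests on a few compounds, and the source may have more. Where it says the series, first, only, none or still open, it means among the compounds named here.

Compound 1 `CC(=O)N1N=C(Nc2nc3ccc(C)cc3s2)CC1c1ccc(O)cc1`: 54.3 umol/kg
Compound 2 `CC(=O)N1N=C(Nc2nc3ccccc3s2)CC1c1ccc(Cl)cc1`: "not determined" (no result reported)
Compound 3 `CC(=O)N1N=C(Nc2nc3ccc(C)cc3s2)CC1OC1=CC=C1`: "not determined" (no result reported)

Going by the values given here, in a functional assay on the whole organism (strain albino) with Mus musculus as the target, with a stated time of 0.5 h (a lower number here means that less compound is needed, a higher number that more compound is needed for the effect), compound 1 gives 54.3 umol/kg and is the only compound with a number. Compound 3 gives "not determined" (no result reported) and so has no place on the numbers, and compound 2 shares that gap with "not determined" (no result reported) as its entry. Compound 4 `CC(=O)N1N=C(Nc2nc3ccc(C)cc3s2)CC1c1ccc(Cl)cc1` is still unmeasured. The structural change is a group of 7 heavy atoms (6 carbon, 1 chlorine; one six-membered aromatic ring of carbon only) in place of a group of 5 heavy atoms (4 carbon, 1 oxygen; one four-membered non-aromatic ring of carbon only), on a saturated ring carbon and it falls on a saturated ring carbon, with 4-chlorophenyl as the entering group. Among the compounds with values here, no measured step exists to show a size or direction in this assay, so the only anchor is compound 1 at 54.3 umol/kg and no step beyond the scatter from that number is expected. For compound 4 the estimated value is 50 umol/kg with an expected range from 20 umol/kg to 130 umol/kg in this measurement.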

Compound 4, dose for half-maximal effect: 27.5 umol/kg
The estimate for compound 4 lay 1.8-fold (0.26 log units) above the measured number, and the stated range covers the measured number.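

In this assay, going by these compounds alone, the one step that can be read is a 2.0-fold lower number from compound 1 to compound 4 (0.30 log units; within the scatter) and so chloro in place of hydroxy on this aromatic carbon does not separate the two compounds. The steps from compound 2 and compound 3 cannot be read. Nothing available explains this result. Still open, going by these compounds, is whether an amine or a carboxylic acid on that aromatic carbon would carry the number beyond the scatter. Also open, on these data alone, is what a longer chain on the saturated ring carbon, in place of 4-chlorophenyl, would give.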